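Swapping a Nitrophenyl for a Dichlorophenyl on Two Cores

A few compounds are considered here, and "the series" means these few. Any claim that something is new, unique, unknown or untested is made for them only; others in the source may bear on it.

Compound 1 `CC(=O)N1N=C(c2cccc3ccccc23)CC1c1ccccc1[N+](=O)[O-]` and compound 2 `CC(=O)N1N=C(c2cccc3ccccc23)CC1c1cccc(Cl)c1Cl` share one core, while compound 3 `O=CCN1N=C(c2ccc3ccccc3c2)CC1c1ccccc1[N+](=O)[O-]` and compound 4 `O=CCN1N=C(c2ccc3ccccc3c2)CC1c1cccc(Cl)c1Cl` share another; the difference between the two cores is not broken down here. In a functional assay on HEp-2 cells (Homo sapiens) for cytotoxicity, read by sulforhodamine B assay, with a stated time of 48 h (on this read-out higher numbers stand for weaker inhibition and lower numbers for stronger inhibition), compound 1 gives 3960 nM and compound 2 gives 16800 nM. The change that separates them is 2,3-dichlorophenyl in place of 2-nitrophenyl on a saturated ring carbon, and it produced a 4.2-fold higher number from compound 1 to compound 2 (0.63 log units; beyond the scatter). In this assay compound 3 gives 3630 nM, a value that lies within the usual scatter of the value of compound 1, whereas compound 2 stands clearly further away.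

Compound 4 has not yet been measured. It differs from compound 3 by 2,3-dichlorophenyl in place of 2-nitrophenyl on a saturated ring carbon. For the measured compounds named here, this is the same kind of change as the one between compound 1 and compound 2, but not the same change: in compound 1 the saturated carbon carrying the group is next to the ring atom that bears an acetyl group, whereas in compound 3 it is next to the ring atom that bears a formylmethyl group. Going by the values given here, only one earlier example of this swap exists, so the expectation rests on it alone. Because the first core showed a 4.2-fold higher number from compound 1 to compound 2 (0.63 log units; beyond the scatter), compound 4 is expected to give about 15000 nM in this assay. For compound 4 the expected range runs from 7000 nM to 35000 nM. This estimate corresponds to a 4.1-fold higher number from compound 3 to compound 4 (0.62 log units; beyond the scatter).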

Compound 4, half-maximal inhibitory concentration: 12500 nM
Estimate against measurement, compound 4: 1.2-fold (0.08 log units) above; measured number inside the range.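

The swap of 2-nitrophenyl for 2,3-dichlorophenyl produced a 3.4-fold higher number from compound 3 to compound 4 (0.54 log units; beyond the scatter) in this assay, and set beside the earlier case, the step is of much the same size on both cores: the same change on two cores in this assay, a 4.2-fold higher number (0.63 log units; beyond the scatter) from compound 1 to compound 2 and a 3.4-fold higher number (0.54 log units; beyond the scatter) from compound 3 to compound 4, 1.2-fold (0.09 log units) apart, within the scatter of two such steps

Within these four compounds, then, the change carries over from the core of compound 1 to the core of compound 3, and in both pairs the number rises, which on this read-out means weaker inhibition. For the compounds shown here, this does not show that the change would behave the same way on any other core, since two pairs are only two examples, and it says nothing about why the number rises or how the two cores compare with each other.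

Going by these compounds, the saturated ring carbon carries only these two groups here, so it remains open how a plain phenyl, a methoxyphenyl or a phenyl with a single chlorine would fit between or beyond them. On these data alone, it is equally open whether the step would keep its size if the acetyl or formylmethyl group gave way to a longer chain, or to a chain ending in an amine or a carboxylic acid.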